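The source may hold more compounds than are shown below. What is called first, only, known or untested is meant among the compounds shown, and "the series" means these compounds.

Measured compounds:
compound 1 `O=C(NCCO)c1cccc2c1CCN2c1cc(Cc2cc(F)cc(C(F)(F)F)c2)ncn1` — in a functional assay on HEK293 cells for agonist activity at G-protein coupled receptor 52 (Homo sapiens), read by cAMP accumulation, with a stated time of 15 min (a lower number here means that less compound is needed, a higher number that more compound is needed for the effect), compound 1 gives 135 nM
compound 2 `O=C(NCCO)c1cccc2c1CCN2c1nncc(Cc2cc(F)cc(C(F)(F)F)c2)c1Cl` — compound 2 gives 565 nM
compound 3 `O=C(NCCO)c1cccc2c1CCN2c1cc(Cc2cccc(C(F)(F)F)c2)ncn1` — compound 3 gives 101 nM

Compound 3 holds the lowest of the three numbers. Its nearest neighbour is compound 1, and the step from compound 1 to compound 3 a 1.3-fold lower number from compound 1 to compound 3 (0.13 log units; within the scatter) lies within the scatter, so the two are not separated. Compound 2 is furthest away; its number is beyond the scatter from that of compound 3, but compound 2 differs from it in more than one place, so no single step can be read from that pair.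

Compound 4 `O=C(NCCO)c1cccc2c1CCN2c1cc(Cc2ccccc2C(F)(F)F)ncn1` keeps the same atoms as compound 3 and differs only in 2-(trifluoromethyl)phenyl in place of 3-(trifluoromethyl)phenyl on a saturated chain carbon bound to an aromatic carbon. Among the measured compounds shown here, no measured step moves the trifluoromethyl group around its ring; the one single-place step in the set, a 1.3-fold lower number from compound 1 to compound 3 (0.13 log units; within the scatter), removes a fluoro and is within the scatter. The direction of the change is therefore open, and a moderate step of a 2.5-fold higher number from compound 3 to compound 4 (0.39 log units; beyond the scatter) is expected rather than a large one. For compound 4 the estimate in this assay is 250 nM, with a range from 70 nM to 1000 nM.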

Compound 4, half-maximal effective concentration: 711 nM
For compound 4 the middle estimate is 2.8-fold (0.45 log units) below the measured one, and the stated range covers the measured number.
By their numbers in this assay, from the lowest: compounds 3 and 1 (each within the scatter of the next); then compounds 2 and 4 (each within the scatter of the next).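

In this assay, among the compounds shown here, this place on a saturated chain carbon bound to an aromatic carbon responds to where the trifluoromethyl group sits on the ring: 2-(trifluoromethyl)phenyl in place of 3-(trifluoromethyl)phenyl gives a 7.0-fold higher number from compound 3 to compound 4 (0.85 log units; beyond the scatter), with the atoms and counts unchanged, whereas the one earlier single-place step stayed within the scatter. The same group in place of 3-fluoro-5-(trifluoromethyl)phenyl gives a 5.3-fold higher number from compound 1 to compound 4 (0.72 log units; beyond the scatter), so the rise appears against both earlier groups. No measurement at hand accounts for this change.

Open, on these data alone, is whether the effect belongs to trifluoromethyl itself or would follow any group on that ring, which a chloro or nitrile group in the same places would help to separate. Also open, as far as these compounds go, is whether the step carries over to the core of compound 2.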